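Trading Two Chlorines for a Chlorine and a Methyl

A few compounds are considered here, and "the series" means these few. Any claim that something is new, unique, unknown or untested is made for them only; others in the source may bear on it.

Measured so far:
compound 1 `CC/C(=C(/c1ccc(/C=C/C(=O)O)cc1)c1cc2ccccc2[nH]1)c1cccc(F)c1C#N`: 40 nM
compound 2 `CC/C(=C(/c1ccc(/C=C/C(=O)O)cc1)c1cc2ccccc2[nH]1)c1ccc(Cl)cc1Cl`: 11 nM

In a functional assay on MCF7 cells (Homo sapiens) for inhibition (on this read-out lower numbers stand for stronger inhibition and higher numbers for weaker inhibition), compound 1 gives 40 nM and compound 2 gives 11 nM. Among the compounds with values here, compound 2 stands lowest of the two numbers; the only neighbour is compound 1, and the step of a 3.6-fold lower number from compound 1 to compound 2 (0.56 log units; beyond the scatter) is modest but beyond the scatter. Compound 3 `CC/C(=C(/c1ccc(/C=C/C(=O)O)cc1)c1cc2ccccc2[nH]1)c1c(C)cccc1Cl` has not been measured. The change is 2-chloro-6-methylphenyl in place of 2,4-dichlorophenyl on a double-bonded chain carbon bound to a double-bonded chain carbon and a saturated chain carbon; the heavy-atom count stays at eight, with seven carbon and one chlorine instead of six carbon and two chlorine, and no donors or acceptors either way. Within the data shown here, the only measured step at this place is a 3.6-fold lower number from compound 1 to compound 2 (0.56 log units; beyond the scatter), and it compared quite different groups, so it offers little guidance for this swap. Compound 3 is therefore expected to land close to compound 2, with a step of a 1.5-fold higher number from compound 2 to compound 3 (0.16 log units; within the scatter) that may stay within the scatter. The estimate for compound 3 is 16 nM, ranging from 6 nM to 45 nM.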

Compound 3, half-maximal inhibitory concentration: 30 nM
Compound 3: middle estimate off by 1.9-fold (0.27 log units), on the low side; the measured number falls inside the stated range.
By their numbers in this assay, from the lowest: compound 2; then compounds 3 and 1 (each within the scatter of the next).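

In this assay, the step of a 2.7-fold higher number from compound 2 to compound 3 (0.44 log units; beyond the scatter) shows that this position can tell apart two groups with the same number of heavy atoms and no hydrogen-bond donors or acceptors. The step of a 1.3-fold lower number from compound 1 to compound 3 (0.12 log units; within the scatter) stays within the scatter, so 2-chloro-6-methylphenyl and 2-cyano-3-fluorophenyl cannot be separated here, and among these three compounds only the 2,4-dichlorophenyl group of compound 2 stands clearly apart. Nothing available explains these differences.

The 2-chloro-6-methylphenyl group differs from 2,4-dichlorophenyl in more than one respect, so these compounds leave open which difference accounts for the step. Groups such as 2-chloro-4-methylphenyl and 2,6-dichlorophenyl, which are not among the compounds shown, would help to separate those differences.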